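The compounds below may be only part of what the source reports. "The series", "measured", "known", "first", "only" and "open" are said of these compounds alone.

In a functional assay on A549 cells (Homo sapiens) for inhibition, read by MTT assay, with a stated time of 48 h (on this read-out higher numbers stand for weaker inhibition of growth and lower numbers for stronger inhibition of growth), compound 1 `COc1ccc(C(=O)N2N=C(c3ccccc3)CC2c2cn(C)c3ccccc23)cn1` gives 3040 nM, compound 2 `Cn1cc(C2CC(c3ccccc3)=NN2C(=O)c2cccnc2)c2cc(Br)ccc21` gives 1600 nM, and compound 3 `Cn1cc(C2CC(c3ccc(F)cc3)=NN2C(=O)c2cccnc2)c2cc(Br)ccc21` gives 1380 nM. Compound 3 stands level with compound 2 within the scatter, while its value lies under that of compound 1 by a gap beyond the scatter.

Compound 4 `Cn1cc(C2CC(c3ccc(Cl)cc3)=NN2C(=O)c2cccnc2)c2cc(Br)ccc21` departs from compound 3 in one place: chloro in place of fluoro on an aromatic carbon. This is chloro in place of fluoro on an aromatic carbon, or 4-fluorophenyl to 4-chlorophenyl. Among the compounds with values here, no chloro compound has been measured, so the data give no direct reading of this exchange. Within the data shown here, the one measured step on that aromatic carbon is a 1.2-fold lower number from compound 2 to compound 3 (0.06 log units; within the scatter), where fluoro takes the place of hydrogen, and it stays within the scatter. Among the measured compounds shown here, with only that step to go on, no change beyond the scatter is expected in this assay. The expected change is a 1.1-fold lower number from compound 3 to compound 4 (0.03 log units; within the scatter), within the scatter. For compound 4 the estimated value is 1300 nM, with an expected range from 700 nM to 2400 nM.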

Compound 4, concentration for 50% growth inhibition: 7650 nM
Beside the measured number, compound 4's estimate is 5.9-fold (0.77 log units) below it; measured number above the stated range.
By their numbers in this assay, from the lowest: compounds 3, 2 and 1 (each within the scatter of the next, the first and the last beyond it); then compound 4.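

In this assay, this aromatic carbon turns out not to be indifferent to what it carries: the exchange of 4-fluorophenyl for 4-chlorophenyl gives a 5.5-fold higher number from compound 3 to compound 4 (0.74 log units; beyond the scatter), and chloro in place of hydrogen gives a 4.8-fold higher number from compound 2 to compound 4 (0.68 log units; beyond the scatter), whereas fluoro in place of hydrogen gave only a 1.2-fold lower number from compound 2 to compound 3 (0.06 log units; within the scatter). The outcome here therefore depends on which halogen enters, since growth inhibition weakens with chloro but stays level with fluoro. Nothing available bears on the reason for this difference between chloro and fluoro.

From the compounds shown here alone, it remains open whether the weakening is particular to chloro or extends to other groups on this carbon, such as methyl, trifluoromethyl or an amine. Going by these compounds, it also remains open whether chloro would act alike on a core lacking the bromo group.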